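A few compounds are considered here, and "the series" means these few. Any claim that something is new, unique, unknown or untested is made for them only; others in the source may bear on it.

Measured in a functional assay on MCF7 cells (Homo sapiens) for cytotoxicity, read by CellTiter-Glo, with a stated time of 5 days; a lower number here means a stronger inhibitor, a higher number a weaker inhibitor:
- compound 1 `CC/C(=C(/c1ccc(/C=C/C(=O)O)cc1)c1ccc2[nH]ncc2c1)c1cccc(Cl)c1`: 12 nM
- compound 2 `CC/C(=C(/c1ccc(/C=C/C(=O)O)cc1)c1ccc2[nH]ncc2c1)c1ccccc1C#N`: 12 nM

Compound 2, at 12 nM, stands level with compound 1, its nearest neighbour in the series, and neither can be ranked over the other. Next in line is compound 3 `CC/C(=C(/c1ccc(/C=C/C(=O)O)cc1)c1ccc2[nH]ncc2c1)c1cccc(C#N)c1`, which differs from compound 2 as follows: 3-cyanophenyl in place of 2-cyanophenyl on a double-bonded chain carbon bound to a double-bonded chain carbon and a saturated chain carbon. The nitrile stays, and 3-cyanophenyl takes the place of 2-cyanophenyl on a double-bonded chain carbon bound to a double-bonded chain carbon and a saturated chain carbon.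

Within the data shown here, only one measured step bears on this place: no change at the digits printed from compound 1 to compound 2 (within the scatter). That step exchanged 3-chlorophenyl for 2-cyanophenyl and left the reading unmoved, so this place has so far tolerated a change of group. Among the measured compounds shown here, one step is thin evidence, and no measurement yet isolates the move of the nitrile alone. On that basis, no step beyond the scatter is expected in this assay, and no direction can be argued. The expected step is no change at the digits printed from compound 2 to compound 3 (within the scatter). Compound 3 is estimated at 12 nM, with an expected range of 5 nM to 30 nM.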

Compound 3, half-maximal inhibitory concentration: 100 nM
The estimate for compound 3 lay 8.3-fold (0.92 log units) below the measured number; the whole stated range lies below it.
By their numbers in this assay, from the lowest: compounds 1 and 2 (each within the scatter of the next); then compound 3.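

In this assay, the place on a double-bonded chain carbon bound to a double-bonded chain carbon and a saturated chain carbon turns out not to accept every group: 3-cyanophenyl in place of 2-cyanophenyl gives an 8.3-fold higher number from compound 2 to compound 3 (0.92 log units; beyond the scatter) even though the two groups hold the same atoms, so the earlier tolerance does not extend to this change. Cyano in place of chloro on an aromatic carbon gives an 8.3-fold higher number from compound 1 to compound 3 (0.92 log units; beyond the scatter), so the nitrile by itself does not set the reading, since compound 2 also carries one and stands level with compound 1, and among these three only the 3-cyanophenyl of compound 3 stands apart. Nothing on hand speaks to the cause of either step.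

Three compounds cannot show whether 3-cyanophenyl is a lone exception or the first sign of a wider limit at this place. A methoxy or an amine on the same aromatic carbon in place of the nitrile or the chloro would help separate those two readings.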